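Carbamoyl to Dihydroxyethyl: Expected Effect on Growth Inhibition

The compounds below may be only part of what the source reports. "The series", "measured", "known", "first", "only" and "open" are said of these compounds alone.

Measured compounds:
compound 1 `O=C(N[C@@H]1CNCC[C@H]1c1ccc(Cl)cc1)c1ccc(-c2ncnc3c2CCC3O)s1` — 24100 nM
compound 2 `COCC[C@@H]1C[C@@H](c2ccc(Cl)c(Cl)c2)[C@H](NC(=O)c2cc(-c3c(Cl)cnn3C)c(Cl)o2)CN1` — 1060 nM
compound 3 `Cn1ncc(Cl)c1-c1cc(C(=O)N[C@@H]2CN[C@H](CC(N)=O)C[C@H]2c2ccc(Cl)c(Cl)c2)oc1Cl` — 1000 nM

In a functional assay on OVCAR-8 cells (Homo sapiens) for antiproliferative activity (a lower number here means a stronger inhibitor, a higher number a weaker inhibitor), compound 1 gives 24100 nM, while compound 2 gives 1060 nM and compound 3 gives 1000 nM. Compound 3 and compound 2 sit within the scatter of each other, and both stand far from compound 1, which carries a different core. Compound 4 `Cn1ncc(Cl)c1-c1cc(C(=O)N[C@@H]2CN[C@H](CC(O)CO)C[C@H]2c2ccc(Cl)c(Cl)c2)oc1Cl` differs from compound 3 in one place: 1,2-dihydroxyethyl in place of carbamoyl on a saturated chain carbon bound to a saturated ring carbon. Among the compounds with values here, the only measured step at this position is a 1.1-fold lower number from compound 2 to compound 3 (0.03 log units; within the scatter), where one small polar side chain replaced another without moving the number beyond the scatter. The change to compound 4 is of the same kind, a swap of one small polar group for another on the same saturated chain carbon, so a step no larger than the scatter is expected in this assay. Compound 4 is therefore estimated at 1100 nM, with a range of 450 nM to 2700 nM. This estimate means a step of a 1.1-fold higher number from compound 3 to compound 4 (0.04 log units; within the scatter), which is expected to stay within the scatter.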

Compound 4, half-maximal inhibitory concentration: 1610 nM
Compound 4: middle estimate off by 1.5-fold (0.17 log units), on the low side; measured number inside the range.
By their numbers in this assay, from the lowest: compounds 3, 2 and 4 (each within the scatter of the next); then compound 1.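

In this assay the side chain on a saturated chain carbon bound to a saturated ring carbon has now taken three forms without any step leaving the scatter: 1,2-dihydroxyethyl for carbamoyl gives a 1.6-fold higher number from compound 3 to compound 4 (0.21 log units; within the scatter) and 1,2-dihydroxyethyl for methoxymethyl gives a 1.5-fold higher number from compound 2 to compound 4 (0.18 log units; within the scatter). The carbamoyl double bond is therefore not needed to keep the number in this range, since 1,2-dihydroxyethyl has no double bond and still stays within the scatter of both other groups. No measurement bearing on why these three groups read alike is available here.

The compounds shown leave open whether an amine, a carboxylic acid or a longer chain at this place would move the number beyond the scatter. They also leave open whether any group here can do so in either direction.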